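Swapping the Aromatic Group of Compound 3

The compounds below may be only part of what the source reports. "The series", "measured", "known", "first", "only" and "open" are said of these compounds alone.

Measured in a functional assay on MDA-MB-436 cells (Homo sapiens) for antiproliferative activity, read by MTT assay, with a stated time of 48 h; a higher number here means a weaker inhibitor, a lower number a stronger inhibitor:
- Compound 1 `C=CS(=O)(=O)N1CCN(c2ncnc3sc(-c4ccccc4)cc23)CC1`: 21100 nM
- Compound 2 `C=CS(=O)(=O)N1CCN(c2ncnc3sc(-c4ccc(F)nc4)cc23)CC1`: 17500 nM
- Compound 3 `C=CS(=O)(=O)N1CCN(c2ncnc3sc(-c4cn(C)nc4C(F)(F)F)cc23)CC1`: 15100 nM

All three compounds share one core and carry different aromatic groups on the same carbon. Compound 3, at 15100 nM, cannot be separated from the other two, as a 1.4-fold lower number from compound 1 to compound 3 (0.15 log units; within the scatter) and a 1.2-fold lower number from compound 2 to compound 3 (0.06 log units; within the scatter) show. Going by the values given here, compound 4 `C=CS(=O)(=O)N1CCN(c2ncnc3sc(-c4c(C)noc4C)cc23)CC1` keeps the core of compound 3 and changes only this group, on the aromatic carbon next to the ring sulfur: 3,5-dimethyl-1,2-oxazol-4-yl in place of 1-methyl-3-(trifluoromethyl)-1H-pyrazol-4-yl on an aromatic carbon. The measured steps bearing on this change are the three exchanges of that group, namely a 1.2-fold lower number from compound 1 to compound 2 (0.08 log units; within the scatter), together with the two above. Phenyl, 6-fluoropyridin-3-yl and 1-methyl-3-(trifluoromethyl)-1H-pyrazol-4-yl thus gave no step beyond the scatter, so none is expected in this assay for 3,5-dimethyl-1,2-oxazol-4-yl, and no direction can be favoured. The expected change is a 1.1-fold higher number from compound 3 to compound 4 (0.05 log units; within the scatter). For compound 4 the estimated value is 17000 nM, with an expected range from 9000 nM to 32000 nM.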

Compound 4, half-maximal inhibitory concentration: 34600 nM
Estimate against measurement, compound 4: 2.0-fold (0.31 log units) below; the whole stated range lies below it.
By their numbers in this assay, from the lowest: compounds 3, 2, 1 and 4 (each within the scatter of the next, the first and the last beyond it).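

At the aromatic carbon next to the ring sulfur, the exchange of 1-methyl-3-(trifluoromethyl)-1H-pyrazol-4-yl for 3,5-dimethyl-1,2-oxazol-4-yl gives the only step beyond the scatter among these compounds in this assay (a 2.3-fold higher number from compound 3 to compound 4 (0.36 log units; beyond the scatter)). The same group stays within the scatter against the other two, 6-fluoropyridin-3-yl (a 2.0-fold higher number from compound 2 to compound 4 (0.30 log units; within the scatter)) and phenyl (a 1.6-fold higher number from compound 1 to compound 4 (0.21 log units; within the scatter)), so this position shows a modest response to one exchange and none that can be read in the others. Nothing measured here accounts for that step.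

The two five-membered rings differ in their ring atoms and their substituents at once, so the compounds shown cannot assign the step to either difference. All four groups are aromatic rings, which leaves open how an amine, a carboxylic acid or a longer chain on this carbon would behave.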